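Swapping Chloro for Fluoro on Two Related Cores

The compounds below may be only part of what the source reports. "The series", "measured", "known", "first", "only" and "open" are said of these compounds alone.

Compound 1 `O=C(Nc1ccc(F)cc1F)c1cc(F)ccc1O` carries a fluoro group on the ring that also bears the hydroxy group. Compound 2 `O=c1oc2ccc(Br)cc2c(=O)n1-c1ccc(F)cc1F` is built on a different core; the difference between the two cores is not broken down here. In an ADME assay on RAW264.7 cells (Mus musculus) for cytotoxicity, read by MTT assay, with a stated time of 24 h (on this read-out lower numbers stand for higher toxicity in this test and higher numbers for lower toxicity in this test), compound 1 gives 15700 nM, and compound 2 gives 16000 nM, and these two numbers lie within the scatter of each other. Compound 3 `O=c1oc2ccc(Br)cc2c(=O)n1-c1ccc(Cl)cc1F` is compound 2 with a single change, (chloro in place of fluoro on an aromatic carbon). In this assay compound 3 gives 7500 nM, which amounts to a 2.1-fold lower number from compound 2 to compound 3 (0.33 log units; beyond the scatter).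

Compound 4 `O=C(Nc1ccc(F)cc1F)c1cc(Cl)ccc1O` has not been measured yet. It differs from compound 1 by chloro in place of fluoro on an aromatic carbon. Among the compounds with values here, this is the same kind of change as the one from compound 2 to compound 3, but not the same: there the aromatic carbon is meta to a fluoro group and para to a large group, whereas here it is meta to a large group and para to a hydroxy group, and the two cores differ as well. Because a 2.1-fold lower number from compound 2 to compound 3 (0.33 log units; beyond the scatter) was modest yet beyond the scatter, a step of similar size and direction is expected here, though with less certainty given the different surroundings. Compound 4 is expected to give 9000 nM in this assay, with a likely range from 4500 nM to 18000 nM. The estimated step is a 1.7-fold lower number from compound 1 to compound 4 (0.24 log units; within the scatter).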

Compound 4, half-maximal cytotoxic concentration: 14600 nM
Compound 4: the middle estimate sits 1.6-fold (0.21 log units) below what was measured; measured number inside the range.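

In this assay, putting chloro in place of fluoro on the core of compound 1 gives a 1.1-fold lower number from compound 1 to compound 4 (0.03 log units; within the scatter), so on this core the swap produces no difference that can be separated from ordinary repeat-to-repeat variation. Set beside the step on the other core, this result cannot be told apart from it: the same change on two cores in this assay, a 2.1-fold lower number (0.33 log units; beyond the scatter) from compound 2 to compound 3 and a 1.1-fold lower number (0.03 log units; within the scatter) from compound 1 to compound 4, 2.0-fold (0.30 log units) apart, within the scatter of two such steps. One step lies beyond the scatter and the other within it, yet the gap between them is no larger than measurement scatter allows, and with a single pair on each core and the swap sitting in a different place in each pair, these data show neither that the change carries over unaltered nor that its size depends on the core.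

Still open, as far as these compounds go, is how this position, para to a hydroxy group, would respond to groups other than the two halogens, such as a methyl, a methoxy, an amine or a carboxylic acid. Also open, from the compounds shown here alone, is whether the same swap made on the ring of compound 1 that lacks the hydroxy group would come closer to a 2.1-fold lower number from compound 2 to compound 3 (0.33 log units; beyond the scatter) or stay within the scatter.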